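This account rests on a few compounds, and the source may have more. Where it says the series, first, only, none or still open, it means among the compounds named here.

In a functional assay on PC-3 cells (Homo sapiens) for antiproliferative activity, read by MTT assay, with a stated time of 48 h (a lower number here means a stronger inhibitor, a higher number a weaker inhibitor), three compounds that share one core have been measured. Compound 1 `C#CCCOC(=O)c1ccc(C(CC)(CC)c2ccc(OCCC(O)(CC)CC)c(C)c2)n1CC` gives > 50000 nM, which is a limit and not a number. Compound 2 `CCn1c(C(=O)Nc2ccc(OC(F)(F)F)cc2)ccc1C(CC)(CC)c1ccc(OCCC(O)(CC)CC)c(C)c1` gives > 50000 nM, again a limit. Among the compounds with values here, compound 3 `CCOC(=O)C(CC(=O)OC)NC(=O)c1ccc(C(CC)(CC)c2ccc(OCCC(O)(CC)CC)c(C)c2)n1CC` gives 5840 nM, the only actual number among the three. Compound 4 `CCn1c(C(=O)N(C)CCO)ccc1C(CC)(CC)c1ccc(OCCC(O)(CC)CC)c(C)c1` keeps the shared core and differs from compound 3 on a carbonyl carbon, where (2-hydroxyethyl)(methyl)amino enters: a group of 5 heavy atoms (3 carbon, 1 nitrogen, 1 oxygen; no ring) in place of a group of 12 heavy atoms (7 carbon, 1 nitrogen, 4 oxygen; no ring), on a carbonyl carbon. Within the data shown here, two measured steps bear on this change, an at least 8.5-fold lower number from compound 1 to compound 3 (0.93 log units; beyond the scatter) and an at least 8.5-fold lower number from compound 2 to compound 3 (0.93 log units; beyond the scatter), and both lie beyond the scatter. Among the measured compounds shown here, the group that compound 4 gives up is the one that compound 3 alone carries, and the rest of the evidence stands at the limit of > 50000 nM in this assay, at which 2 of the 3 values shown sit. A higher number in this assay is therefore expected, with the estimated step being a 3.8-fold higher number from compound 3 to compound 4 (0.58 log units; beyond the scatter). The reading may well stop at the limit again. For compound 4 the estimated value is 22000 nM, with an expected range from 7000 nM to 50000 nM.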

Compound 4, half-maximal inhibitory concentration: 3090 nM
The estimate for compound 4 lay 7.1-fold (0.85 log units) above the measured number; measured number outside the range, below it.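

In this assay, within the data shown here, a second group on the carbonyl carbon now gives a readable value, and it is far smaller than the one in compound 3: a 1.9-fold lower number from compound 3 to compound 4 (0.28 log units; within the scatter). A readable value at this place is therefore not tied to the group that compound 3 alone carried, and the new steps are an at least 16-fold lower number from compound 2 to compound 4 (1.20 log units; beyond the scatter) and an at least 16-fold lower number from compound 1 to compound 4 (1.20 log units; beyond the scatter). Both of these steps start from a limit and not from a number: the limit of > 50000 nM in this assay, at which 2 of the 4 values shown sit.

The compounds shown leave open which part of (2-hydroxyethyl)(methyl)amino goes with the readable value, and whether dimethylamino, a carboxylic acid or a longer hydroxyalkyl chain on the same carbonyl carbon would read or stop at the limit. The two numbers lie within the scatter of each other and give no order between these groups.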